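Replacing a thioamide-type chain by a carboxy group

The source may hold more compounds than are shown below. What is called first, only, known or untested is meant among the compounds shown, and "the series" means these compounds.

Going by the values given here, compound 2, `C/N=C(/S)CCCCCn1nc(-c2ccccc2)ccc1=O`, has the higher of the two numbers measured so far. In a functional assay on the whole organism (stomach) for inhibition, with Rattus norvegicus as the target, at a dose of 100 mg/kg by the intraduodenal route (a lower number here means less inhibition, a higher number more inhibition at the dose given (going by the name of the read-out)), compound 2 gives 92.3%, whereas compound 1, `CCOC(=O)CCn1nc(-c2ccccc2)ccc1=O`, gives 6.3% in this assay. Among the compounds with values here, the single step between them, a number 86 percentage points higher from compound 1 to compound 2 (beyond the scatter), is the only guide available here, and it is large.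

Compound 3, `O=C(O)CCn1nc(-c2ccccc2)ccc1=O`, is the next compound, and it is not yet measured. It differs from compound 2 in one place: a group of 3 heavy atoms (1 carbon, 2 oxygen; no ring) in place of a group of 7 heavy atoms (5 carbon, 1 nitrogen, 1 sulfur; no ring), on a saturated chain carbon, two bonds along the chain from an aromatic nitrogen. Within the data shown here, the group that leaves is exactly the one whose arrival in compound 2 brought the large rise over compound 1, and what enters, a carboxy group, is closer in make-up to the oxygen-bearing group of compound 1 than to the sulfur-bearing chain of compound 2. The step of a number 86 percentage points higher from compound 1 to compound 2 (beyond the scatter) is therefore the one that bears on this change, and it suggests that taking the 7-heavy-atom group away should cost most of that gain.

The step from compound 2 to compound 3 is expected to be a large fall, a number 74.3 percentage points lower from compound 2 to compound 3 (beyond the scatter). Compound 3 is estimated to give 18% in this assay, somewhere between 0% and 50%.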

Compound 3, a percentage reported as inhibition, in the whole organism at one dose (the size of the read-out at that dose, not a potency): 26.1%
Estimate against measurement, compound 3: 8.1 percentage points below; low and high end bracket the measured number.
By their numbers in this assay, from the lowest: compound 1; then compound 3; then compound 2.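

In this assay, putting the carboxy group in place of the sulfur-bearing chain of compound 2 gives a number 66.2 percentage points lower from compound 2 to compound 3 (beyond the scatter), even though both groups show the same counts of hydrogen-bond donors and acceptors, so those counts alone do not separate a high number from a low one at this place. The second step shows that a much smaller change at the same place also registers: hydrogen in place of ethyl on the oxygen gives a number 19.8 percentage points higher from compound 1 to compound 3 (beyond the scatter), which is modest beside the fall from compound 2, and both compounds with the oxygen-bearing end stay far from the number of compound 2. The compounds shown offer no measurement that explains either step.

The compounds shown leave open whether the high number of compound 2 belongs to the longer chain or to the sulfur-bearing end, since the two change together in every step that involves it. A carboxylic acid carried on the longer chain, or the sulfur-bearing end carried on the shorter one, would pull these two apart, and an amine at the end of the chain would show whether other groups can stand there.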